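A few compounds are considered here, and "the series" means these few. Any claim that something is new, unique, unknown or untested is made for them only; others in the source may bear on it.

Compound 1 `CN1CCN(c2ccc(Nc3ncc4nc([S+]([O-])Cc5cccnc5)n(C5CCOCC5)c4n3)cc2)CC1` gives in a functional assay on HCC827 cells (Homo sapiens) for antiproliferative activity, read by MTT assay, with a stated time of 72 h (a lower number here means a stronger inhibitor, a higher number a weaker inhibitor), only a limit, > 10000 nM. Within the data shown here, compound 2 `CN1CCN(c2ccc(Nc3ncc4nc(SCc5cccnc5)n(C5CCOCC5)c4n3)cc2)CC1` gives 500 nM in this assay, the sole plain number in the set. Among the measured compounds shown here, the single measured step, an at least 20-fold lower number from compound 1 to compound 2 (1.30 log units; beyond the scatter), concerns the sulfur group and not the ring nitrogen substituent. Compound 3 `CN1CCN(c2ccc(Nc3ncc4nc(SCc5cccnc5)n(C5CC5)c4n3)cc2)CC1` carries cyclopropyl in place of oxan-4-yl on an aromatic nitrogen. No measured step touches this position, so nothing shown speaks for or against a change. The estimate for compound 3 is therefore a 1.2-fold higher number from compound 2 to compound 3 (0.08 log units; within the scatter) in this assay, a step not expected to exceed the scatter. Compound 3 is expected near 600 nM, between 200 nM and 2500 nM.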

Compound 3, half-maximal inhibitory concentration: 8830 nM
Beside the measured number, compound 3's estimate is 15-fold (1.17 log units) below it; measured number above the stated range.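

The substituent on the aromatic nitrogen is not a silent position: cyclopropyl in place of oxan-4-yl gives an 18-fold higher number from compound 2 to compound 3 (1.25 log units; beyond the scatter) in this assay. With the ((pyridin-3-yl)methyl)sulfanyl group unchanged, this substituent alone is enough for a large step, so the sulfur group is not the only sensitive place in the series. Nothing shown gives a cause for this loss.

Still open, from the compounds shown here alone, is whether ring size or the ring oxygen of oxan-4-yl carries the difference. Cyclohexyl or piperidin-4-yl at this nitrogen would separate the two.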